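The source may hold more compounds than are shown below. What is called first, only, known or untested is meant among the compounds shown, and "the series" means these compounds.

Measured compounds:
Compound 1 `O=C(NC(=S)NNc1ncnc2ccccc12)c1ccccc1F` gives 5010 nM in a functional assay on MGC-803 cells (Homo sapiens) for cytotoxicity, read by MTT assay, with a stated time of 72 h; on this read-out higher numbers stand for weaker inhibition and lower numbers for stronger inhibition.
Compound 2 `COc1cc2ncnc(NNC(=S)NC(=O)c3ccc(Cl)cc3)c2cc1OC` gives 3710 nM in this assay.
Compound 3 `COc1cc2ncnc(NNC(=S)NC(=O)c3ccccc3OC)c2cc1OC` gives 1590 nM in this assay.

Compound 2 holds the second highest of the three numbers in this assay. Its nearest neighbour is compound 1, whose value sits within the scatter of its own, so the two cannot be told apart on these data. Among the compounds with values here, the only number that stands clearly apart is that of compound 3, reached by the step of a 2.3-fold lower number from compound 2 to compound 3 (0.37 log units; beyond the scatter).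

Compound 4 `COc1cc2ncnc(NNC(=S)NC(=O)c3ccc(F)cc3)c2cc1OC` differs from compound 2 in a single place: fluoro in place of chloro on an aromatic carbon. Within the data shown here, no measured step exchanges one halogen for another; the step from compound 2 to compound 3 replaces the whole substituted ring and so bears only loosely on this change. Compound 1 carries a 2-fluorophenyl on a different core, and its value and that of compound 2 lie within the scatter of each other, which offers no lead either way.

He therefore expects no step beyond the scatter for compound 4 in this assay, amounting to a 1.1-fold higher number from compound 2 to compound 4 (0.03 log units; within the scatter). His estimate for compound 4 is 4000 nM, with a range from 2000 nM to 8000 nM.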

Compound 4, half-maximal inhibitory concentration: 8300 nM
Compound 4: middle estimate off by 2.1-fold (0.32 log units), on the low side; the measured number lies above the stated range.
By their numbers in this assay, from the lowest: compound 3; then compounds 2, 1 and 4 (each within the scatter of the next, the first and the last beyond it).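

The exchange of 4-chlorophenyl for 4-fluorophenyl on the carbonyl is the first swap of one halogen for another among these compounds, and in this assay it produces a 2.2-fold higher number from compound 2 to compound 4 (0.35 log units; beyond the scatter) and so shows that this position responds to a change of a single heavy atom, even though the counted hydrogen-bond donors and acceptors stay the same. The same fluoro compound also stands well away from the 2-methoxyphenyl compound, with a 5.2-fold higher number from compound 3 to compound 4 (0.72 log units; beyond the scatter) as the largest step read so far between compounds that differ in one place, so the choice of group on this ring matters more than the earlier step alone suggested. No measured property of these groups bears on the result, and the data offer no explanation for either step.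

Still open, on these data alone, is how this position would respond if an amine, a hydroxyl or a carboxylic acid stood in place of the halogen on the same ring. The compounds shown also leave open whether the exchange of chloro for fluoro would read the same way on the core of compound 1, which carries a 2-fluorophenyl instead.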